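Chloro in place of methyl on compound 3

This account rests on a few compounds, and the source may have more. Where it says the series, first, only, none or still open, it means among the compounds named here.

- compound 1 `Cc1ccc(NC(=O)C[C@H](CCC(=O)O)c2noc(-c3nnc(CC(C)C)s3)c2C2CC2)c(Cl)c1` gives 3.4
- compound 2 `Cc1ccc(NC(=O)C[C@H](CCC(=O)O)c2noc(-c3cc(C(F)(F)CC(C)C)on3)c2C2CC2)c(Cl)c1` gives 4.4
- compound 3 `Cc1ccc(NC(=O)C[C@H](CCC(=O)O)c2noc(-c3cc(CC(C)(C)C)on3)c2C2CC2)c(Cl)c1` gives 4.2

In a physicochemical assay for lipophilicity (on this read-out lower numbers stand for lower lipophilicity and higher numbers for higher lipophilicity), compound 3 (4.2) lies within the scatter of compound 2 (4.4), and compound 1 (3.4) falls lower than both, beyond the scatter.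

Compound 4 `CC(C)(C)Cc1cc(-c2onc([C@@H](CCC(=O)O)CC(=O)Nc3ccc(Cl)cc3Cl)c2C2CC2)no1` differs from compound 3 in one place (chloro in place of methyl on an aromatic carbon), with chloro in place of methyl on an aromatic carbon, para to a large group.

Going by the values given here, no measured step touches that place. The three available steps all exchange a different group: a number 1.00 log units higher from compound 1 to compound 2 (beyond the scatter), a number 0.80 log units higher from compound 1 to compound 3 (beyond the scatter) and a number 0.20 log units lower from compound 2 to compound 3 (within the scatter). They set no direct size for this change, and the estimate rests on compound 3 (4.2) as its starting point. No shift beyond the scatter is expected in this assay, and a slight rise is the likelier direction, though no measurement supports it yet. The expected change is a number 0.20 log units higher from compound 3 to compound 4 (within the scatter) (an estimate only). The estimated value for compound 4 is 4.4 (expected range 4 to 4.8).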

Compound 4, distribution coefficient: 4.2
Compound 4: the middle estimate sits 0.20 log units above what was measured; low and high end bracket the measured number.
By their numbers in this assay, from the lowest: compound 1; then compounds 3, 4 and 2 (each within the scatter of the next).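

In this assay, chloro in place of methyl on the aromatic carbon para to a large group gives no change at the digits printed from compound 3 to compound 4 (within the scatter) for this first reading at this place. On this background, 2-chloro-4-methylphenyl and 2,4-dichlorophenyl therefore cannot be told apart on this read-out, whereas exchanging 5-isobutyl-1,3,4-thiadiazol-2-yl for 5-neopentyl-1,2-oxazol-3-yl gives a number 0.80 log units higher from compound 1 to compound 3 (beyond the scatter). No available data bear on why the two groups read alike.

The compounds shown leave open whether a group other than methyl or chloro at this place, such as an amine, a nitrile or a trifluoromethyl, would move the number beyond the scatter. They also leave open whether chloro in place of methyl would read the same with the 5-isobutyl-1,3,4-thiadiazol-2-yl group of compound 1.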